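Acetyl for dimethylamino on the pendant phenyl ring

The source may hold more compounds than are shown below. What is called first, only, known or untested is meant among the compounds shown, and "the series" means these compounds.

Compound 1 `COc1cc(C)cc(-c2c(-c3ccnc(-c4ccc(N(C)C)cc4)c3)cnn2CC#N)c1` is taken as the reference point of the series. In a functional assay on EKVX cells (Homo sapiens) for inhibition, read by sulforhodamine B assay, with a stated time of 48 h (a lower number here means that less compound is tolerated, a higher number that more compound is tolerated), compound 1 returns > 100000 nM, which is a limit of the assay and not a number. Compound 2 `COc1cc(C)cc(-c2nn(CC#N)cc2-c2ccnc(-c3ccc(N(C)C)cc3)c2)c1` is a second member of the same set. In this assay compound 2 likewise sits at a limit, > 100000 nM. Compound 3 `Cc1cc(O)cc(-c2nn(CC#N)cc2-c2ccnc(-c3ccc(Oc4ccccc4)cc3)c2)c1` gives > 100000 nM in this assay, again a limit rather than a number. Compound 1 therefore stands where every measured member stands, as the limit of > 100000 nM in this assay, at which 3 of the 3 values shown sit, shows. Within the data shown here, no step between measured compounds can be sized from such readings, so no direction is established for any change of this kind.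

Compound 4 `COc1cc(C)cc(-c2c(-c3ccnc(-c4ccc(C(C)=O)cc4)c3)cnn2CC#N)c1` is not yet measured. It differs from compound 1 as follows: acetyl in place of dimethylamino on an aromatic carbon. With all three measured values resting at the limit, the step of a number no higher from compound 1 to compound 4 (the limit leaves the size open) is expected to be none beyond the scatter, and another limit reading is the expected outcome. Compound 4 is accordingly estimated at 100000 nM, within a range from 30000 nM to 300000 nM.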

Compound 4, concentration lethal to 50% of the cells: > 100000 nM
Compound 4 ended at the assay's limit; the forecaster's own chance of this, stated with the estimate: 80%; the middle value lies on the limit itself.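

In this assay compound 4 gives > 100000 nM, a limit of the assay and not a number. No step can be read between compound 1 and compound 4, as both rest at the same reading: the limit of > 100000 nM in this assay, at which 4 of the 4 values shown sit.

The compounds shown leave open whether acetyl and dimethylamino differ at all in this assay, since none of them gives a value inside the measurable range.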